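The compounds below may be only part of what the source reports. "The series", "measured", "known", "first", "only" and "open" are said of these compounds alone.

Three measured compounds, one pending. Compound 1 `N[C@@H](COP(=O)(O)O[C@@H]1CCCO[C@@H]1COC(=O)CCc1ccccc1OCc1cccc(Oc2ccc(Cl)cc2)c1)C(=O)O` and compound 2 `N[C@@H](COP(=O)(O)O[C@@H]1CCCO[C@@H]1COC(=O)CCc1ccccc1OCc1cccc(Oc2ccccc2)c1)C(=O)O` share one core; compound 3 `N[C@@H](COP(=O)(O)OC[C@H]1OCCC[C@H]1OC(=O)CCc1ccccc1OCc1cccc(Oc2ccccc2)c1)C(=O)O` has the same atoms joined differently, and the difference between the two cores is not broken down here. In an assay on HEK293-A cells for agonist activity at probable G-protein coupled receptor 34 (Mus musculus), with a stated time of 1.5 h (on this read-out higher numbers stand for larger maximal responses and lower numbers for smaller maximal responses), compound 1 gives 16.6%, compound 2 gives 14.8% and compound 3 gives 17.7%; the three numbers lie within the scatter of one another.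

Among the compounds with values here, the one counted change among the measured compounds is chloro in place of hydrogen on an aromatic carbon, which gave a number 1.8 percentage points higher from compound 2 to compound 1 (within the scatter). Compound 4 `N[C@@H](COP(=O)(O)OC[C@H]1OCCC[C@H]1OC(=O)CCc1ccccc1OCc1cccc(Oc2ccc(Cl)cc2)c1)C(=O)O` carries the same change on the core of compound 3: chloro in place of hydrogen on an aromatic carbon. The step expected in this assay is a number 1.3 percentage points higher from compound 3 to compound 4 (within the scatter), resting on a number 1.8 percentage points higher from compound 2 to compound 1 (within the scatter) and on compound 3 standing at 17.7%. Compound 4 is accordingly estimated at 19%, with a likely range from 11% to 27%.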

Compound 4, largest response reached (Emax), in percent of the reference or control that the assay uses: 15.1%
For compound 4 the middle estimate is 3.9 percentage points above the measured one; the measured number falls inside the stated range.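

In this assay, phenoxy to 4-chlorophenoxy gives a number 2.6 percentage points lower from compound 3 to compound 4 (within the scatter). Set beside the earlier step, the two cores do not separate: the same change on two cores in this assay, a number 1.8 percentage points higher (within the scatter) from compound 2 to compound 1 and a number 2.6 percentage points lower (within the scatter) from compound 3 to compound 4, 4.4 percentage points apart, within the scatter of two such steps. The change therefore stays within the scatter on both cores, and the opposite signs of the two steps carry no weight; the pairs show neither that the change carries over with a common size nor that the cores respond to it differently.

Open, from the compounds shown here alone, is whether an amine or a carboxylic acid in the place of the chloro would move the maximal response beyond the scatter. Also open, going by these compounds, is whether a longer chain in the ester would do so on either core.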